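Phenyl for thiophen-2-yl on the pyrazole-bearing side chain

The source may hold more compounds than are shown below. What is called first, only, known or untested is meant among the compounds shown, and "the series" means these compounds.

Measured in a functional assay on PC-9 cells (Homo sapiens) for inhibition, read by MTT assay, with a stated time of 72 h; a higher number here means a weaker inhibitor, a lower number a stronger inhibitor:
- compound 1 `Cc1cc(Nc2cc(-c3ccccc3)[nH]n2)n2ncnc2n1`: a limit of the assay, > 50000 nM
- compound 2 `Cc1cc(Nc2cc(-c3ccccc3)[nH]n2)n2nc(SCc3cccc(Br)c3)nc2n1`: 8900 nM
- compound 3 `Cc1cc(Nc2cc(-c3cccs3)[nH]n2)n2nc(SCc3ccc(Br)cc3)nc2n1`: 4890 nM

Compound 3 carries the lowest of the two numbers shown, but compound 2 lies within the usual scatter of it, so no order between them can be claimed. Among the compounds with values here, the only measured step, an at least 5.6-fold lower number from compound 1 to compound 2 (0.74 log units; beyond the scatter), concerns the (3-bromobenzyl)sulfanyl group and not the aryl on the five-membered ring, so it does not bear on the change considered here.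

Compound 4 `Cc1cc(Nc2cc(-c3ccccc3)[nH]n2)n2nc(SCc3ccc(Br)cc3)nc2n1` differs from compound 3 by phenyl in place of thiophen-2-yl on an aromatic carbon. Within the data shown here, no measured step covers such an aryl swap, so in this assay no step beyond the scatter is expected in either direction. Compound 4 is therefore estimated at 6000 nM, within 2000 nM to 20000 nM, which means an expected step of a 1.2-fold higher number from compound 3 to compound 4 (0.09 log units; within the scatter).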

Compound 4, half-maximal inhibitory concentration: 4760 nM
Compound 4: the middle estimate sits 1.3-fold (0.10 log units) above what was measured; the measured number falls inside the stated range.
By their numbers in this assay, from the lowest: compounds 4, 3 and 2 (each within the scatter of the next). At a limit, above all of these: compound 1.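

On an aromatic carbon of the five-membered aromatic ring with 2 nitrogen, phenyl and thiophen-2-yl give no readable difference (a 1.0-fold lower number from compound 3 to compound 4 (0.01 log units; within the scatter)). The 4-bromophenyl and 3-bromophenyl groups on the saturated chain carbon bound to a sulfur likewise stay within the scatter (a 1.9-fold lower number from compound 2 to compound 4 (0.27 log units; within the scatter)). The gain from (4-bromobenzyl)sulfanyl in place of hydrogen (an at least 10-fold lower number from compound 1 to compound 4 (1.02 log units; beyond the scatter)) is measured against compound 1, which sits at a limit: (the limit of > 50000 nM in this assay, at which 1 of the 4 values shown sits).

Open, as far as these compounds go, is whether an amine or a carboxylic acid in place of phenyl would shift the number. The same holds for a longer chain in place of the benzyl group on sulfur.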